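Removing the aryl group from a quinoline thiosemicarbazone

A few compounds are considered here, and "the series" means these few. Any claim that something is new, unique, unknown or untested is made for them only; others in the source may bear on it.

Compound 2 `Cc1cccc(NC(=S)N/N=C/c2ccc3ccccc3n2)c1` is measured in a functional assay on HeLa cells (Homo sapiens) for antiproliferative activity, read by sulforhodamine B assay, with a stated time of 72 h (on this read-out lower numbers stand for stronger inhibition and higher numbers for weaker inhibition), and gives > 100000 nM, which is a limit of the assay rather than a number. Compound 1 `COc1ccc(C)cc1NC(=S)N/N=C/c1ccc2ccccc2n1` also gives only a limit in this assay, namely > 100000 nM. The step from compound 1 to compound 2, a step that the two limits leave unreadable from compound 1 to compound 2, therefore cannot be read in size, because the limit of > 100000 nM in this assay, at which 2 of the 3 values shown sit, hides whatever difference the two may have. Compound 3 `NC(=S)N/N=C/c1cc2ccccc2s1` carries an unsubstituted thiosemicarbazone on a different core and in this assay gives 6770 nM, a number well inside the measurable range. Compound 4 `NC(=S)N/N=C/c1ccc2ccccc2n1` differs from compound 2 by hydrogen in place of 3-methylphenyl on an amide-type nitrogen. Among the compounds with values here, no measured step tracks this change directly. Within the data shown here, the only guidance is that compound 3, with the same free thiosemicarbazone nitrogen, gives 6770 nM. Compound 2 gives only a limit of the assay. Compound 4 is therefore expected to show a step of an at least 8.3-fold lower number from compound 2 to compound 4 (0.92 log units; beyond the scatter) toward stronger inhibition, though the size is uncertain. Compound 4 is estimated at 12000 nM, within a range from 2000 nM to 100000 nM.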

Compound 4, half-maximal inhibitory concentration: 960 nM
Beside the measured number, compound 4's estimate is 13-fold (1.10 log units) above it, and the stated range ends above it.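

Within the data shown here, putting hydrogen in place of 3-methylphenyl on the amide-type nitrogen gives an at least 100-fold lower number from compound 2 to compound 4 (2.01 log units; beyond the scatter) in this assay, the only step in this set that can be read. Earlier, the aryl-bearing compounds had given only limits, so they could not show whether this nitrogen mattered at all; with the free nitrogen, the same core now gives a number well inside the measurable range. The printed size is a bound and not a full measure, because compound 2 stays at a limit: the limit of > 100000 nM in this assay, at which 2 of the 4 values shown sit.

From the compounds shown here alone, what remains open is whether any group on this nitrogen brings the same loss or only an aryl group does. A methyl group, a longer alkyl chain or a benzyl group at this place would separate these cases.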